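Swapping an aromatic ring for a small ring

This account rests on a few compounds, and the source may have more. Where it says the series, first, only, none or still open, it means among the compounds named here.

Compound 1 `COc1cc(-c2nnc3n2NC(c2ccco2)C(C(=O)c2ccccc2F)S3)cc(OC)c1OC` carries a 2-fluorophenyl group on a carbonyl carbon. In a functional assay on MCF7 cells (Homo sapiens) for cytotoxicity, read by MTT assay, with a stated time of 48 h (on this read-out lower numbers stand for stronger inhibition and higher numbers for weaker inhibition), compound 1 gives 94800 nM. Compound 2 `COc1cc(-c2nnc3n2NC(c2ccco2)C(C(=O)c2cccs2)S3)cc(OC)c1OC` reaches only a limit of this assay, > 100000 nM. Compound 3 `COc1cc(-c2nnc3n2NC(c2ccco2)C(C(=O)c2ccc(Cl)cc2)S3)cc(OC)c1OC` likewise reaches only a limit of this assay, > 100000 nM. The steps of an at least 1.0-fold higher number from compound 1 to compound 2 (0.02 log units; that floor lies within the scatter) and an at least 1.0-fold higher number from compound 1 to compound 3 (0.02 log units; that floor lies within the scatter) stay within the scatter, and the step that the two limits leave unreadable from compound 2 to compound 3 cannot be read, since the limit of > 100000 nM in this assay, at which 2 of the 3 values shown sit, holds two of the three values. Compound 4 `COc1cc(-c2nnc3n2NC(c2ccco2)C(C(=O)C2CC2)S3)cc(OC)c1OC` differs from compound 3 by cyclopropyl in place of 4-chlorophenyl on a carbonyl carbon. Among the measured compounds shown here, no measured step covers this change, so no shift beyond the scatter is expected; the estimated step is a number no higher from compound 3 to compound 4 (the limit leaves the size open). Compound 4 is therefore expected to give 100000 nM, within 40000 nM to 300000 nM, most likely again only a limit of this assay.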

Compound 4, half-maximal inhibitory concentration: > 100000 nM
Compound 4: no number, only a limit (the forecaster's own chance of this, stated with the estimate: 70%); the middle value sits exactly at the limit.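

Compound 4 shows that on this carbonyl carbon the limit is not tied to an aromatic ring: with cyclopropyl, too, no number can be read. Among the compounds shown here, only one step to it can be read, an at least 1.0-fold higher number from compound 1 to compound 4 (0.02 log units; that floor lies within the scatter), and the steps from the other two limit compounds cannot be read. The series thus gathers at a single limit: the limit of > 100000 nM in this assay, at which 3 of the 4 values shown sit.

Still open, as far as these compounds go, is whether an amine or a carboxylic acid on this carbonyl carbon would give a number clear of that limit. Also open, from the compounds shown here alone, is whether a change elsewhere on the shared core would do so.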